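The source may hold more compounds than are shown below. What is called first, only, known or untested is meant among the compounds shown, and "the series" means these compounds.

Of the compounds shown here, two have been measured so far in a functional assay on COR-L23 cells (Homo sapiens) for antiproliferative activity, read by CellTiter-Glo, with a stated time of 72 h; on this read-out higher numbers stand for weaker inhibition and lower numbers for stronger inhibition. Compound 1 (`C[C@H](NC(=O)c1ncccn1)c1ccc(NC(=O)N2CC(c3cccnc3)C2)cc1`) gives 130 nM, and compound 2 (`C[C@@H](c1ccc(NC(=O)N2CC(c3cncc(N)c3)C2)cc1)N1Cc2ccccc2C1=O`) gives 130 nM, so compound 2 stands level with compound 1, within the scatter of repeated measurements. Compound 3 (`C[C@H](NC(=O)c1ncccn1)c1ccc(NC(=O)N2CC(c3cncc(N)c3)C2)cc1`) has not yet been measured. It derives from compound 2 through a single structural change: a group of 9 heavy atoms (5 carbon, 3 nitrogen, 1 oxygen; one six-membered aromatic ring with 2 hetero atoms) in place of a group of 10 heavy atoms (8 carbon, 1 nitrogen, 1 oxygen; one five-membered non-aromatic ring with 1 hetero atom, one six-membered aromatic ring of carbon only), on a saturated chain carbon bound to an aromatic carbon and a saturated chain carbon. The group that enters, ((pyrimidin-2-yl)carbonyl)amino, is also carried by compound 1, which gives 130 nM in this assay. For the measured compounds named here, no measured pair isolates this change, so the data offer no direct guide to its effect. Going by the values given here, the only indication is that compound 2, at 130 nM, and compound 1 show the same value despite their different structures. On that basis, no shift beyond the scatter is expected in this assay, and neither direction is clearly favoured. The expected size of the change is a 1.3-fold lower number from compound 2 to compound 3 (0.11 log units; within the scatter). For compound 3, the estimated half-maximal inhibitory concentration is 100 nM, with an expected range from 30 nM to 350 nM.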

Compound 3, half-maximal inhibitory concentration: 1380 nM
Beside the measured number, compound 3's estimate is 14-fold (1.14 log units) below it; measured number outside the range, above it.
By their numbers in this assay, from the lowest: compounds 1 and 2 (each within the scatter of the next); then compound 3.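

In this assay, the saturated chain carbon bound to an aromatic carbon proves sensitive to its substituent once the amino group is present: ((pyrimidin-2-yl)carbonyl)amino in place of the group with the five-membered non-aromatic ring gives an 11-fold higher number from compound 2 to compound 3 (1.03 log units; beyond the scatter), a large step beyond the scatter. The amino group is not a neutral addition either, since amino in place of hydrogen on an aromatic carbon gives an 11-fold higher number from compound 1 to compound 3 (1.03 log units; beyond the scatter), so with ((pyrimidin-2-yl)carbonyl)amino on the chain carbon the amino group costs as much as the change of group does, which the equal numbers of the two earlier compounds gave no hint of. No measurement at hand gives a reason for either step.

The compounds shown do not tell whether amino in place of hydrogen would have any effect alongside the group of compound 2, so it stays open whether the loss belongs to the amino group alone or to its pairing with ((pyrimidin-2-yl)carbonyl)amino. Also open, going by these compounds, is how a methyl group or a hydroxyl group would fare in place of the amino group, or how an acetylamino group would fare on the chain carbon.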